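The source may hold more compounds than are shown below. What is called first, only, known or untested is meant among the compounds shown, and "the series" means these compounds.

Measured so far in a functional assay on HUVEC cells (Homo sapiens), read by fluorescence and microscopy, with a stated time of 6 h, tested at 10 uM; a lower number here means a stronger effect, a higher number a weaker effect of the compound at the concentration tested: compound 1 `N#Cc1c(Nc2ccc(C(F)(F)F)cc2)sc2ccccc12` gives 24%; compound 2 `N#Cc1c(Nc2ccc([N+](=O)[O-])cc2)sc2ccccc12` gives 8%; compound 3 `N#Cc1c(Nc2cccc(O)c2)sc2ccccc12` gives 0%.

Compound 3 holds the lowest of these three numbers. Compound 2 lies within the usual scatter of it, whereas compound 1 sits beyond the scatter above it. Compound 4 `N#Cc1c(Nc2ccccc2)sc2ccccc12` differs from compound 3 by hydrogen in place of hydroxy on an aromatic carbon. Within the data shown here, the one measured step, a number 16 percentage points lower from compound 1 to compound 2 (beyond the scatter), concerns an exchange of a different group and does not bear directly on the loss of a hydroxy; no measured pair tests that change. With compound 3 already at the floor of the read-out, the number for compound 4 is expected to stay near it or move upward, a number 12 percentage points higher from compound 3 to compound 4 (beyond the scatter). Compound 4 is therefore estimated at 12%, between 0% and 35%.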

Compound 4, a percentage reported as activity, at one concentration (the size of the read-out at that concentration, not a potency): 81%
The estimate for compound 4 lay 69 percentage points below the measured number, and the stated range ends below it.
By their numbers in this assay, from the lowest: compounds 3 and 2 (each within the scatter of the next); then compound 1; then compound 4.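

In this assay, hydrogen in place of hydroxy on this aromatic carbon gives a number 81 percentage points higher from compound 3 to compound 4 (beyond the scatter), showing that the low number depends on a group being present there. The other two groups show the same: hydrogen in place of nitro gives a number 73 percentage points higher from compound 2 to compound 4 (beyond the scatter), and hydrogen in place of trifluoromethyl gives a number 57 percentage points higher from compound 1 to compound 4 (beyond the scatter), so all three substituted compounds lie well below compound 4. No measurement here accounts for this. From the compounds shown here alone, whether an amine, a methoxy group or a carboxylic acid would also hold the number low remains open.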